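Replacing the dimethoxyphenyl of compound 3 with fluorophenyl

A few compounds are considered here, and "the series" means these few. Any claim that something is new, unique, unknown or untested is made for them only; others in the source may bear on it.

Measured compounds:
compound 1 `COc1cccc(C(=O)c2ccc3c(ccn3S(=O)(=O)c3cccc(/C=C/C(=O)NO)c3)c2)c1`, 1810 nM
compound 2 `Cc1ccc(C(=O)c2ccc3c(ccn3S(=O)(=O)c3cccc(/C=C/C(=O)NO)c3)c2)cc1`, 2750 nM
compound 3 `COc1ccc(C(=O)c2ccc3c(ccn3S(=O)(=O)c3cccc(/C=C/C(=O)NO)c3)c2)cc1OC`, 1180 nM

In an assay on isolated protein for inhibition of protein deacetylase HDAC6 (Homo sapiens) (a lower number here means a stronger inhibitor, a higher number a weaker inhibitor), compound 3 gives the lowest number of the three, but only its gap to compound 2 lies beyond the scatter, as a 2.3-fold lower number from compound 2 to compound 3 (0.37 log units; beyond the scatter) shows; a 1.5-fold lower number from compound 1 to compound 3 (0.19 log units; within the scatter) stays within it. Compound 4 `O=C(/C=C/c1cccc(S(=O)(=O)n2ccc3cc(C(=O)c4ccc(F)cc4)ccc32)c1)NO` differs from compound 3 by 4-fluorophenyl in place of 3,4-dimethoxyphenyl on a carbonyl carbon. Among the compounds with values here, two measured steps bear on this: a 1.5-fold higher number from compound 1 to compound 2 (0.18 log units; within the scatter) was within the scatter, and a 2.3-fold lower number from compound 2 to compound 3 (0.37 log units; beyond the scatter) was modest. Both point to a somewhat higher number when the methoxy groups are removed, so compound 4 is expected to sit near compound 2, with a step of about a 2.1-fold higher number from compound 3 to compound 4 (0.33 log units; beyond the scatter). Compound 4 is therefore estimated at 2500 nM, within a range of 1200 nM to 5200 nM.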

Compound 4, half-maximal inhibitory concentration: 1420 nM
Beside the measured number, compound 4's estimate is 1.8-fold (0.25 log units) above it; low and high end bracket the measured number.
By their numbers in this assay, from the lowest: compounds 3, 4, 1 and 2 (each within the scatter of the next, the first and the last beyond it).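

In this assay the 4-fluorophenyl group on a carbonyl carbon stays within the scatter of each earlier group: 3,4-dimethoxyphenyl (a 1.2-fold higher number from compound 3 to compound 4 (0.08 log units; within the scatter)), 3-methoxyphenyl (a 1.3-fold lower number from compound 1 to compound 4 (0.11 log units; within the scatter)) and 4-methylphenyl (a 1.9-fold lower number from compound 2 to compound 4 (0.29 log units; within the scatter)). Within the data shown here, the methoxy groups can thus be replaced, and fluoro can stand in place of methyl, without a step beyond the scatter, so the one such step seen earlier does not mark methoxy as needed here. No available evidence accounts for this. The compounds shown leave open whether a morpholine or a carboxylic acid in place of the substituted phenyl would move the number beyond the scatter.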